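The compounds below may be only part of what the source reports. "The series", "measured", "known", "first", "only" and "open" are said of these compounds alone.

Measured so far in an assay on HEK293 cells for displacement of a labelled ligand from NPC1-like intracellular cholesterol transporter 1 (Homo sapiens); a higher number here means a weaker inhibitor, a lower number a stronger inhibitor:
compound 1, `CC(C)(C)OC(=O)NCC1CCCN(C(=O)CN2CN(c3ccccc3)C3(CCN(C(=O)c4ccc(C5CCCCC5)cc4)CC3)C2=O)C1`: compound 1 gives 3800 nM
compound 2, `CC(C)(C)c1ccc(C(=O)N2CCC3(CC2)C(=O)N(CC(=O)NCCCN)CN3c2ccccc2)cc1`: compound 2 gives 4200 nM
compound 3, `CC(C)(C)OC(=O)NC1CCCN(C(=O)CN2CN(c3ccccc3)C3(CCN(C(=O)c4ccc(C5CCCCC5)cc4)CC3)C2=O)C1`: compound 3 gives 4400 nM

The three numbers sit close together. Compound 2 stands second highest of the three, yet its gaps to compound 3 and to compound 1 are both within the scatter, so no order among them can be read. Within the data shown here, the only step between compounds that differ in a single place is a 1.2-fold higher number from compound 1 to compound 3 (0.06 log units; within the scatter), which puts (tert-butoxycarbonyl)amino in place of ((tert-butoxycarbonyl)amino)methyl on a saturated ring carbon and stays within the scatter.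

Compound 4, `CC(C)(C)c1ccc(C(=O)N2CCC3(CC2)C(=O)N(CC(=O)NCCCCN)CN3c2ccccc2)cc1`, is not yet measured. It differs from compound 2 by aminomethyl in place of amino on a saturated chain carbon, three bonds along the chain from an amide-type nitrogen. Among the measured compounds shown here, the only measured step that bears on this is the one from compound 1 to compound 3, which is the same kind of chain lengthening in reverse, though there the amine carries a tert-butoxycarbonyl group and the chain sits on a ring carbon; that step was within the scatter. Nothing measured points to a change in either direction. The expected step is therefore no change at the digits printed from compound 2 to compound 4 (within the scatter), none beyond the scatter. Compound 4 is estimated at 4200 nM, with a range from 1800 nM to 10000 nM.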

Compound 4, half-maximal inhibitory concentration: 14500 nM
Estimate against measurement, compound 4: 3.5-fold (0.54 log units) below; measured number outside the range, above it.
By their numbers in this assay, from the lowest: compounds 1, 2 and 3 (each within the scatter of the next); then compound 4.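

In this assay, this chain position is sensitive to length: going from 3-aminopropyl to 4-aminobutyl gives a 3.5-fold higher number from compound 2 to compound 4 (0.54 log units; beyond the scatter), making compound 4 the weakest inhibitor shown and the first clear separation in the series. The same kind of difference on a saturated ring carbon, between ((tert-butoxycarbonyl)amino)methyl and (tert-butoxycarbonyl)amino, gave only a 1.2-fold higher number from compound 1 to compound 3 (0.06 log units; within the scatter), so the insensitivity seen in that pair does not carry over to the free amine chain on the compound 2 scaffold. Nothing available accounts for the loss at this position, so the step stands as an observation without an explanation.

Among these compounds, with only two chain lengths carrying a free amine, it remains open whether the trend continues in either direction, for instance whether a 2-aminoethyl chain restores or improves on the value of compound 2, or whether a 5-aminopentyl chain weakens binding further. Also unresolved is whether the loss depends on the amine at all, which a hydroxyl, a carboxylic acid or a tert-butoxycarbonyl-protected amine on the same chains could test.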